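Swapping a Chlorophenyl for a Fluorophenyl on the Core

This account rests on a few compounds, and the source may have more. Where it says the series, first, only, none or still open, it means among the compounds named here.

Compound 1 `COc1n[nH]c2ncc(C#Cc3c(F)ccc(NS(=O)(=O)c4cccnc4)c3F)cc12` carries a methoxy group on the shared core, and in a functional assay on COLO 205 cells (Homo sapiens) for antiproliferative activity, read by MTT assay, with a stated time of 68 h (a lower number here means a stronger inhibitor, a higher number a weaker inhibitor), compound 1 gives 89 nM. Compound 2 `O=S(=O)(Nc1ccc(F)c(C#Cc2cnc3[nH]nc(-c4cccc(Cl)c4)c3c2)c1F)c1cccnc1` has 3-chlorophenyl in place of that methoxy. In this assay compound 2 reaches only the limit > 10000 nM, a boundary of the measurement rather than a number. Compound 3 `O=S(=O)(Nc1ccc(F)c(C#Cc2cnc3[nH]nc(-c4ccc(F)cc4)c3c2)c1F)c1cccnc1` differs from compound 2 in one place: 4-fluorophenyl in place of 3-chlorophenyl on an aromatic carbon. For the measured compounds named here, no measured step compares two aryl groups at this position. Going by the values given here, the one step that bears on it is an at least 110-fold higher number from compound 1 to compound 2 (2.05 log units; beyond the scatter), in which an aryl group replaced methoxy, and its size is known only as far as the limit of > 10000 nM in this assay, at which 1 of the 2 values shown sits, allows. Compound 3 keeps an aryl group there, so the expected step of a number no higher from compound 2 to compound 3 (the limit leaves the size open) is none beyond the scatter. Compound 3 is expected to give about 10000 nM, within 2000 nM to 40000 nM.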

Compound 3, half-maximal inhibitory concentration: 166 nM
Estimate against measurement, compound 3: 60-fold (1.78 log units) above; measured number outside the range, below it.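

In this assay, 4-fluorophenyl in place of 3-chlorophenyl gives an at least 60-fold lower number from compound 2 to compound 3 (1.77 log units; beyond the scatter), so an aryl group on this aromatic carbon does not by itself abolish activity. Against the original methoxy group, the same 4-fluorophenyl gives a 1.9-fold higher number from compound 1 to compound 3 (0.27 log units; within the scatter), which means the two groups cannot be told apart here and the large loss seen with compound 2 does not extend to compound 3. The true size of both steps involving compound 2 stays unknown, for its value is a limit and not a number: the limit of > 10000 nM in this assay, at which 1 of the 3 values shown sits.

Compounds 2 and 3 differ in both the halogen and its place on the phenyl ring, and the compounds shown cannot separate these two changes; 4-chlorophenyl or 3-fluorophenyl would do so. From the compounds shown here alone, how an amine or a longer chain on this carbon would behave also remains open.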